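From 3-Methoxyphenyl to 4-Methoxyphenyl on a Shared Core

A few compounds are considered here, and "the series" means these few. Any claim that something is new, unique, unknown or untested is made for them only; others in the source may bear on it.

Of the compounds shown here, three with a shared core have been measured in a functional assay on MCF7 cells (Homo sapiens) for antiproliferative activity, read by MTT assay, with a stated time of 24 h; on this read-out lower numbers stand for stronger inhibition and higher numbers for weaker inhibition. Compound 1 `c1ccc(Cc2nnc(Cn3nnc4ccccc43)o2)cc1` gives 258000 nM, compound 2 `Brc1cccc(Cc2nnc(Cn3nnc4ccccc43)o2)c1` gives 269000 nM, and compound 3 `COc1cccc(Cc2nnc(Cn3nnc4ccccc43)o2)c1` gives 241000 nM. Compound 3 thus stands within the scatter of both other compounds, so the three cannot be ranked.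

The next structure is compound 4 `COc1ccc(Cc2nnc(Cn3nnc4ccccc43)o2)cc1`, an isomer of compound 3 with the same atoms joined differently. The change is 4-methoxyphenyl in place of 3-methoxyphenyl on a saturated chain carbon bound to an aromatic carbon, with 4-methoxyphenyl in place of 3-methoxyphenyl on a saturated chain carbon bound to an aromatic carbon.

Among the measured compounds shown here, no measured pair shows this exact change, so the evidence is indirect. Adding a methoxy group gives a 1.1-fold lower number from compound 1 to compound 3 (0.03 log units; within the scatter). Bromo in place of hydrogen gives a 1.0-fold higher number from compound 1 to compound 2 (0.02 log units; within the scatter), and methoxy in place of bromo gives a 1.1-fold lower number from compound 2 to compound 3 (0.05 log units; within the scatter). All three steps lie within the scatter, and these few compounds offer no sign that the change will matter. No step beyond the scatter is therefore expected in this assay, on the strength of the methoxy step a 1.1-fold lower number from compound 1 to compound 3 (0.03 log units; within the scatter) and its two companions. The estimated step is a 1.0-fold higher number from compound 3 to compound 4 (0.02 log units; within the scatter). Compound 4 is expected at about 250000 nM, with an estimated range of 165000 nM to 380000 nM.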

Compound 4, half-maximal inhibitory concentration: 251000 nM
Estimate against measurement, compound 4: 1.0-fold (0.00 log units) below; the measured number falls inside the stated range.
By their numbers in this assay, from the lowest: compounds 3, 4, 1 and 2 (each within the scatter of the next).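

Moving the methoxy group, with 4-methoxyphenyl in place of 3-methoxyphenyl on a saturated chain carbon bound to an aromatic carbon, gives a 1.0-fold higher number from compound 3 to compound 4 (0.02 log units; within the scatter) in this assay. Among the compounds shown here, this is the first direct reading of where the group sits on the phenyl ring rather than whether it is there, and at this position the shift leaves the number within the scatter. The same holds for 4-methoxyphenyl against the other two groups, with a 1.0-fold lower number from compound 1 to compound 4 (0.01 log units; within the scatter) against the unsubstituted phenyl and a 1.1-fold lower number from compound 2 to compound 4 (0.03 log units; within the scatter) against 3-bromophenyl, so the four compounds form one unranked group, and nothing in the data at hand points to a cause for this flat picture.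

From the compounds shown here alone, what remains open is whether any change at this position can produce a step beyond the scatter, for example an amine or a carboxylic acid on the phenyl ring, or a longer chain in place of the saturated chain carbon. The compounds shown also leave open whether the same flat picture would hold for changes elsewhere on the shared core.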